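A few compounds are considered here, and "the series" means these few. Any claim that something is new, unique, unknown or untested is made for them only; others in the source may bear on it.

Among the measured compounds shown here, in a functional assay on HCT-116 cells (Homo sapiens) for cytotoxicity, read by fluorescence, with a stated time of 72 h (a higher number here means a weaker inhibitor, a lower number a stronger inhibitor), compound 1 `CC(C)c1n[nH]c2c(NCc3ccc(-c4ccccn4)cc3)nc(NCCO)nc12` gives 27 nM, the lower of the two numbers so far, and compound 2 `CC(C)c1n[nH]c2c(NCc3ccc(-c4ccccn4)cc3)nc(N3CCCCC3CCO)nc12` gives 142 nM. Compound 3 `CC(C)c1n[nH]c2c(NCc3ccc(-c4ccccn4)cc3)nc(NCc3ccc(-c4ccccn4)cc3)nc12` differs from compound 1 by 4-(pyridin-2-yl)phenyl in place of hydroxymethyl on a saturated chain carbon bound to a nitrogen on an aromatic ring, with 4-(pyridin-2-yl)phenyl in place of hydroxymethyl on a saturated chain carbon bound to a nitrogen on an aromatic ring. For the measured compounds named here, only one measured step bears on this change, at the same side chain: a 5.3-fold higher number from compound 1 to compound 2 (0.72 log units; beyond the scatter), modest but beyond the scatter. Going by the values given here, a step of similar size towards a higher number is therefore expected in this assay, though no measured compound carries this group at that side chain. The expected step is a 4.8-fold higher number from compound 1 to compound 3 (0.68 log units; beyond the scatter). For compound 3 the estimated value is 130 nM, with an expected range of 35 nM to 500 nM.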

Compound 3, half-maximal inhibitory concentration: 7330 nM
Compound 3: middle estimate off by 56-fold (1.75 log units), on the low side; measured number above the stated range.
By their numbers in this assay, from the lowest: compound 1; then compound 2; then compound 3.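

At this place, on a saturated chain carbon bound to a nitrogen on an aromatic ring, this assay shows that the side chain can cost far more than the earlier 5.3-fold higher number from compound 1 to compound 2 (0.72 log units; beyond the scatter) suggested. Putting 4-(pyridin-2-yl)phenyl in place of hydroxymethyl gives a 270-fold higher number from compound 1 to compound 3 (2.43 log units; beyond the scatter). No measurement at hand gives a reason for this drop.

The compounds shown leave open whether the loss of hydroxymethyl or the entry of the two aromatic rings accounts for it. A plain phenyl or an aminomethyl group at this place would bear on that question.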